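Two Amines Measured, an Allyl Analogue Still Open

The source may hold more compounds than are shown below. What is called first, only, known or untested is meant among the compounds shown, and "the series" means these compounds.

Compound 1 `[O-][n+]1nc(NCc2ccccc2Cl)[n+]([O-])c2ccccc21`: 10600 nM
Compound 2 `[O-][n+]1nc(NC2CCCCC2)[n+]([O-])c2ccccc21`: 10500 nM

In a functional assay on PC-3 cells (Homo sapiens) for cytotoxicity, read by MTT assay, with a stated time of 48 h (a higher number here means a weaker inhibitor, a lower number a stronger inhibitor), compound 1 gives 10600 nM and compound 2 gives 10500 nM, two numbers that lie within the scatter of each other, so neither can be called stronger. Compound 3 `C=CCNc1n[n+]([O-])c2ccccc2[n+]1[O-]` is not yet measured. It differs from compound 2 in one place: allyl in place of cyclohexyl on a nitrogen on an aromatic ring. Going by the values given here, no measured pair shows what such a change does here, so a step from compound 2 to compound 3 of no more than the scatter is expected, in either direction. Compound 3 is expected to give about 12000 nM in this assay, between 5000 nM and 30000 nM, which means an estimated step of a 1.1-fold higher number from compound 2 to compound 3 (0.06 log units; within the scatter).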

Compound 3, half-maximal inhibitory concentration: > 56000 nM
Compound 3 was reported as a limit; the forecaster's own chance of this, stated with the estimate: 10%; middle value at least 4.6-fold (0.66 log units) away from the limit.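

In this assay the reading for compound 3 is a limit, not a number: the limit of > 56000 nM in this assay, at which 1 of the 3 values shown sits. Compound 1 and compound 2 carry very different groups on this nitrogen yet sit within the scatter of each other, so they gave no sign that this position could matter. It does: allyl in place of cyclohexyl brings an at least 5.3-fold higher number from compound 2 to compound 3 (0.72 log units; beyond the scatter), and vinyl in place of 2-chlorophenyl brings an at least 5.2-fold higher number from compound 1 to compound 3 (0.72 log units; beyond the scatter).

From the compounds shown here alone, what stays open is whether this step goes with the double bond or with the loss of the ring. A propyl chain on the same nitrogen would separate the two.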